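Chloro for methyl on the sulfonyl aryl across two cores

The source may hold more compounds than are shown below. What is called first, only, known or untested is meant among the compounds shown, and "the series" means these compounds.

Compound 1 `Cc1ccc(S(=O)(=O)N2C(=O)NCC2c2ccc(Br)cc2)cc1` and compound 2 `O=C1NCC(c2ccc(Br)cc2)N1S(=O)(=O)c1ccc(Cl)cc1` share one core. In a functional assay on SK-MEL-2 cells (Homo sapiens) for cytotoxicity (on this read-out higher numbers stand for weaker inhibition and lower numbers for stronger inhibition), compound 1 gives 80000 nM, and compound 2 gives 106000 nM. The change between them is chloro in place of methyl on an aromatic carbon, and the step it made is a 1.3-fold higher number from compound 1 to compound 2 (0.12 log units; within the scatter). Compound 3 `Cc1ccc(S(=O)(=O)N2CC(c3ccccc3)NC2=O)cc1` rests on a different core; in this assay compound 3 gives 2530 nM, the lowest of the three numbers, with compound 1 beyond the scatter above it. The difference between the two cores is not broken down here. Compound 4 `O=C1NC(c2ccccc2)CN1S(=O)(=O)c1ccc(Cl)cc1` carries the same change on the core of compound 3: chloro in place of methyl on an aromatic carbon. For compound 4 a step of a 1.2-fold higher number from compound 3 to compound 4 (0.07 log units; within the scatter) is expected because the earlier step of a 1.3-fold higher number from compound 1 to compound 2 (0.12 log units; within the scatter) stayed within the scatter. In this assay compound 4 is estimated at 3000 nM, between 1200 nM and 8000 nM.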

Compound 4, half-maximal inhibitory concentration: 1430 nM
Estimate against measurement, compound 4: 2.1-fold (0.32 log units) above; low and high end bracket the measured number.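

On the core of compound 3, chloro in place of methyl gives a 1.8-fold lower number from compound 3 to compound 4 (0.25 log units; within the scatter), so in this assay this change stays within the scatter on a second core. The opposite signs of the two steps carry no weight, and the steps do not differ: the same change on two cores in this assay, a 1.3-fold higher number (0.12 log units; within the scatter) from compound 1 to compound 2 and a 1.8-fold lower number (0.25 log units; within the scatter) from compound 3 to compound 4, 2.3-fold (0.37 log units) apart, within the scatter of two such steps. This shows that 4-methylphenyl to 4-chlorophenyl left the number unresolved from scatter on both cores, but it does not show that the change would behave the same way on any further core, and it gives no measurable effect of the change to carry over.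

Going by these compounds, whether an amine or a carboxylic acid in that same place would move the number on either core remains open. On these data alone, what separates the two cores in this assay also remains open.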